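A Methyl on the Ring Nitrogen of Compound 1

A few compounds are considered here, and "the series" means these few. Any claim that something is new, unique, unknown or untested is made for them only; others in the source may bear on it.

Compound 1, `COc1cccc(-c2cc3[nH]nc(N)c3c(=O)[nH]2)c1`, is one of two compounds tested in an assay on isolated protein for inhibition of RAC-alpha serine/threonine-protein kinase (Homo sapiens), read by mobility shift assay, tested at 30 uM; on this read-out lower numbers stand for less inhibition and higher numbers for more inhibition at the one concentration tested (going by the name of the read-out). Among the compounds with values here, compound 1 gives 4%, the smaller of the two numbers measured, although the gap to its only neighbour lies within the usual scatter. Compound 2, `COc1ccc(-c2cc3c(c(N)nn3C)c(=O)[nH]2)cc1`, gives 9% in this assay. Compound 3, `COc1cccc(-c2cc3c(c(N)nn3C)c(=O)[nH]2)c1`, awaits measurement and differs from compound 1 by methyl in place of hydrogen on an aromatic nitrogen. Within the data shown here, no measured pair shows this change on its own, so nothing can be read off directly. The step is expected to be small, if any, with a slight upward lean: a number 3 percentage points higher from compound 1 to compound 3 (within the scatter). Compound 3 is accordingly estimated at 7%, between -4% and 18%.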

Compound 3, a percentage reported as inhibition, at one concentration (the size of the read-out at that concentration, not a potency): -5%
Compound 3: the middle estimate sits 12 percentage points above what was measured, and the stated range ends above it.
By their numbers in this assay, from the lowest: compounds 3, 1 and 2 (each within the scatter of the next, the first and the last beyond it).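

Within the data shown here, compound 3 gives the first direct reading of methyl in place of hydrogen on this aromatic nitrogen: in this assay the change gives a number 9 percentage points lower from compound 1 to compound 3 (within the scatter). At the one concentration tested, this step does not separate compound 3 from compound 1, so adding methyl here brings no gain in inhibition that can be told from the scatter. Nothing available explains the size of this step. Going by these compounds, it remains open whether an ethyl group, or a longer chain ending in an amine, on this nitrogen would give a step beyond the scatter.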